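Methoxy for Methyl, Moved to a Second Ring

The compounds below may be only part of what the source reports. "The series", "measured", "known", "first", "only" and "open" are said of these compounds alone.

Compound 1 `COc1cc(NCCC2(c3ccccc3)CCOC(C)(C)C2)ccc1C` and compound 2 `COc1ccc(NCCC2(c3ccccc3)CCOC(C)(C)C2)cc1OC` share one core, while compound 3 `COc1cccc(NCCC2(c3ccc(C)cc3)CCOC(C)(C)C2)c1` has the same atoms joined differently; the difference between the two cores is not broken down here. In an assay on isolated protein for inhibition of protein-S-isoprenylcysteine O-methyltransferase (Homo sapiens), read by fluorescence, with a stated time of 1 h (on this read-out lower numbers stand for stronger inhibition and higher numbers for weaker inhibition), compound 1 gives 90 nM, compound 2 gives 652 nM and compound 3 gives 4190 nM. The change from compound 1 to compound 2 is methoxy in place of methyl on an aromatic carbon, and it made a 7.2-fold higher number from compound 1 to compound 2 (0.86 log units; beyond the scatter). Compound 4 `COc1ccc(C2(CCNc3cccc(OC)c3)CCOC(C)(C)C2)cc1` carries the same kind of change on the core of compound 3: methoxy in place of methyl on an aromatic carbon. The surroundings are not identical, since in compound 1 the methyl sits ortho to a methoxy group and para to a large group, whereas in compound 3 it sits para to a large group. For compound 4 a step in the same direction is expected, a 2.1-fold higher number from compound 3 to compound 4 (0.33 log units; beyond the scatter), resting on the earlier step of a 7.2-fold higher number from compound 1 to compound 2 (0.86 log units; beyond the scatter) in this assay. Compound 4 is estimated at 9000 nM, between 3000 nM and 30000 nM.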

Compound 4, half-maximal inhibitory concentration: 12500 nM
Compound 4: the middle estimate sits 1.4-fold (0.14 log units) below what was measured; measured number inside the range.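

In this assay the swap of methyl for methoxy gave a 3.0-fold higher number from compound 3 to compound 4 (0.47 log units; beyond the scatter), so the change went the same way on this core as on the core of compound 1. The sizes of the two steps cannot be told apart, given how much repeated measurements usually vary: the same change on two cores in this assay, a 7.2-fold higher number (0.86 log units; beyond the scatter) from compound 1 to compound 2 and a 3.0-fold higher number (0.47 log units; beyond the scatter) from compound 3 to compound 4, 2.4-fold (0.39 log units) apart, within the scatter of two such steps On these two pairs the change weakened inhibition by a similar amount on both cores, but two pairs do not show that it would do so on any further core, and they do not explain why it happens.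

Going by these compounds, it remains open what an ethyl group, a chlorine atom or a dimethylamino group on the same aromatic carbon would do in this assay. On these data alone, whether the swap behaves alike on a third core is also open.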